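From a Carboxymethoxy Chain to a Plain Acetyl

A few compounds are considered here, and "the series" means these few. Any claim that something is new, unique, unknown or untested is made for them only; others in the source may bear on it.

Among the measured compounds shown here, only two compounds have been measured so far. In a functional assay on NCI-H441 cells (Homo sapiens) for antiproliferative activity, with a stated time of 24 h (on this read-out higher numbers stand for weaker inhibition and lower numbers for stronger inhibition), compound 1 `OC1/C(=C/c2ccccc2F)CNC/C1=C\c1ccccc1F` gives 124000 nM, while compound 2 `O=C(O)COCC(=O)N1C/C(=C\c2ccccc2F)C(=O)/C(=C/c2ccccc2F)C1` gives 310000 nM. Compound 2 therefore holds the higher of the two numbers, and the gap lies beyond the usual scatter, making it the weaker inhibitor of this pair.

Compound 3 `CC(=O)N1C/C(=C\c2ccccc2F)C(=O)/C(=C/c2ccccc2F)C1` has not yet been measured. It departs from compound 2 in one place: hydrogen in place of carboxymethoxy on a saturated chain carbon bound to a carbonyl carbon. Put simply, this is hydrogen in place of carboxymethoxy on a saturated chain carbon bound to a carbonyl carbon, so the longer chain is cut back to acetyl.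

For the measured compounds named here, no measured step isolates this change, so the forecast is uncertain. Going by the values given here, the only hint is that compound 1, which carries no such chain, gives 124000 nM, although its core differs as well. A moderate move to a lower number in this assay, beyond the scatter, is therefore expected. The estimated change is a 5.2-fold lower number from compound 2 to compound 3 (0.71 log units; beyond the scatter). The estimate for compound 3 is 60000 nM, with an expected range of 10000 nM to 250000 nM.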

Compound 3, half-maximal inhibitory concentration: 54000 nM
Compound 3: middle estimate off by 1.1-fold (0.05 log units), on the high side; measured number inside the range.
By their numbers in this assay, from the lowest: compound 3; then compound 1; then compound 2.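

In this assay, replacing carboxymethoxy with hydrogen on a saturated chain carbon bound to a carbonyl carbon gives a 5.7-fold lower number from compound 2 to compound 3 (0.76 log units; beyond the scatter), a modest step. This is the first comparison shown in which only this one place changes, so the effect of the chain can now be read without a difference in the core getting in the way. With everything else held the same, the plain acetyl goes with stronger inhibition than the longer chain, which shows that the 5 heavy atoms of carboxymethoxy are not needed for the activity seen on this read-out. Nothing measured here explains why the number falls.

This single step compares only the whole carboxymethoxy group with hydrogen, so it cannot show which part of the chain accounts for the difference. It also leaves open how this place would respond to a methoxy group, an amine or a longer plain carbon chain, and whether the same change would give a similar step on a different core.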